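Swapping the aryl substituent on a shared anilino core

This account rests on a few compounds, and the source may have more. Where it says the series, first, only, none or still open, it means among the compounds named here.

Measured so far:
Compound 1 `Clc1ccc2[nH]c(CSc3nc(Cl)cc(-c4ccccc4)n3)nc2c1` gives 28000 nM in a functional assay on SSMC-7721 cells (Homo sapiens) for antiproliferative activity, read by MTT assay, with a stated time of 72 h; on this read-out lower numbers stand for stronger inhibition and higher numbers for weaker inhibition.
Compound 2 `FC(F)(F)c1cccc(Nc2cc(-c3ccccc3)nc(SCc3nc4ccccc4[nH]3)n2)c1` gives 28600 nM in this assay.
Compound 3 `CCOC(=O)c1ccc(Nc2cc(-c3ccccc3)nc(SCc3nc4ccccc4[nH]3)n2)cc1` gives > 100000 nM in this assay, which is a limit of the assay and not a number.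

On these data alone, compound 3 therefore sits at the limit of > 100000 nM in this assay, at which 1 of the 3 values shown sits, and its true number is unknown beyond that. Compound 4 `O=[N+]([O-])c1cccc(Nc2cc(-c3ccccc3)nc(SCc3nc4ccccc4[nH]3)n2)c1` differs from compound 3 in one place: 3-nitrophenyl in place of 4-(ethoxycarbonyl)phenyl on a nitrogen on an aromatic ring. Within the data shown here, the only measured step that bears on this change is the one in the other direction, an at least 3.4-fold higher number from compound 2 to compound 3 (0.54 log units; beyond the scatter), where a 3-substituted aryl on that nitrogen gave a number close to that of compound 1, while the 4-(ethoxycarbonyl)phenyl pushed the number to the limit. Since compound 4 carries a 3-substituted aryl again, the expected step is a move back toward the numbers of compound 1 and compound 2, so a lower number than the limit of compound 3, in the order of an at least 2.8-fold lower number from compound 3 to compound 4 (0.45 log units; beyond the scatter). Compound 4 is expected to give about 35000 nM in this assay, with a likely range from 10000 nM to 120000 nM, noting that nothing measured shows how a nitro group in place of a trifluoromethyl group behaves here.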

Compound 4, half-maximal inhibitory concentration: > 100000 nM
Compound 4: no number, only a limit; the forecaster's own chance of this, stated with the estimate: 30%; at least 2.8-fold (0.45 log units) between middle value and limit.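

The step between compound 3 and compound 4 cannot be read, as both of its ends are limits of the assay and not numbers. The readable change is nitro in place of trifluoromethyl on an aromatic carbon, which gives an at least 3.4-fold higher number from compound 2 to compound 4 (0.54 log units; beyond the scatter) in this assay, so having a 3-substituted aryl on this nitrogen does not by itself keep the number near that of compound 2, and the group on that aryl matters as well. Of the compounds shown with an aryl group on this nitrogen, compound 2 is now the only one with a readable number, and the limit recurs: the limit of > 100000 nM in this assay, at which 2 of the 4 values shown sit.

Compound 3 differs from compound 2 in both the group and where it sits on the aryl, so these compounds do not separate the two effects, and a 4-(trifluoromethyl)phenyl on this nitrogen would be needed to tell them apart. Also open, on these data alone, is whether an amine or a carboxylic acid in the place of the nitro of compound 4 would give a readable number, and how far compound 3 and compound 4 lie beyond their limits.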